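One Ring Swapped in a Growth Inhibitor

This account rests on a few compounds, and the source may have more. Where it says the series, first, only, none or still open, it means among the compounds named here.

In a functional assay on DU-145 cells (Homo sapiens) for inhibition, read by trypan blue exclusion, with a stated time of 96 h (on this read-out lower numbers stand for stronger inhibition of growth and higher numbers for weaker inhibition of growth), compound 1 `Cc1ccc(S(=O)(=O)/C(=C/c2sccc2C)C(=O)c2ccc(Cl)cc2)cc1` gives 10000 nM and compound 2 `O=C(/C(=C\c1c[nH]c2ccccc12)S(=O)(=O)Cc1ccc(F)cc1)c1ccc(Cl)cc1` gives 50000 nM as the higher of the two numbers, a gap beyond the scatter. Compound 3 `Cc1ccsc1/C=C(\C(=O)c1ccc(Cl)cc1)S(=O)(=O)Cc1ccc(F)cc1` carries 3-methylthiophen-2-yl in place of 1H-indol-3-yl on a double-bonded chain carbon bound to a double-bonded chain carbon and awaits measurement. Compound 1 also bears 3-methylthiophen-2-yl, though it differs elsewhere, and stands at 10000 nM in this test. The expected change is a 3.3-fold lower number from compound 2 to compound 3 (0.52 log units; beyond the scatter) in the direction of stronger inhibition. For compound 3 the estimated value is 15000 nM with an expected range from 4000 nM to 50000 nM on this read-out.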

Compound 3, concentration for 50% growth inhibition: 10000 nM
Beside the measured number, compound 3's estimate is 1.5-fold (0.18 log units) above it, and the stated range covers the measured number.
By their numbers in this assay, from the lowest: compounds 1 and 3 (each within the scatter of the next); then compound 2.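

Putting 3-methylthiophen-2-yl in place of 1H-indol-3-yl on a double-bonded chain carbon bound to a double-bonded chain carbon gives a 5.0-fold lower number from compound 2 to compound 3 (0.70 log units; beyond the scatter) in this assay and shows that the growth read-out responds to the ring at this position. With 3-methylthiophen-2-yl in place, 4-fluorobenzyl instead of 4-methylphenyl on the sulfonyl sulfur gives no change at the digits printed from compound 1 to compound 3 (within the scatter) and so leaves the read-out unmoved. No supporting measurement explains the effect of the ring swap. On these data alone, whether a thiophene without its methyl group, or an amine on the ring, would shift the number further remains open.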